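The source may report more compounds than this note shows. Statements on the series, on what has been measured and on what is new or still open speak of the compounds shown alone.

Compound 1, `N#Cc1cc(F)cc(C(=O)Nc2ccccc2F)c1`: > 30000 nM
Compound 2, `N#Cc1cc(F)cc(C(=O)Nc2ccccc2Cl)c1`: > 30000 nM
Compound 3, `COc1ccccc1NC(=O)c1cc(F)cc(C#N)c1`: > 30000 nM

Each of the three values is a limit of the assay rather than a measured number. In an in vitro functional assay on HEK293-A cells for antagonist activity at metabotropic glutamate receptor 5 (Rattus norvegicus), read by calcium flux (on this read-out higher numbers stand for weaker inhibition and lower numbers for stronger inhibition), compound 1 gives > 30000 nM, which is a limit and says only that no inhibition strong enough to measure was seen. Compound 2 shows the same limit. Compound 3 shows it as well. Accordingly, the three single-point changes among the measured compounds, a step that the two limits leave unreadable from compound 1 to compound 2, a step that the two limits leave unreadable from compound 1 to compound 3 and a step that the two limits leave unreadable from compound 2 to compound 3, cannot be read for size or direction, since the limit of > 30000 nM in this assay, at which 3 of the 3 values shown sit, is where all three sit.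

Compound 4, `N#Cc1cc(F)cc(C(=O)Nc2cccc(Cl)c2F)c1`, differs from compound 1 by chloro in place of hydrogen on an aromatic carbon. For the measured compounds named here, none of the measured steps is readable, so there is no basis for expecting a move of any particular size in this assay, and the shared core of compound 1 has so far given no measurable value at all. The most reasonable expectation is that compound 4 stays close to where compound 1 stands, with a step of a number no higher from compound 1 to compound 4 (the limit leaves the size open) expected. Compound 4 is therefore estimated at 30000 nM, with a range from 5000 nM to 100000 nM.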

Compound 4, half-maximal inhibitory concentration: 347 nM
Beside the measured number, compound 4's estimate is 86-fold (1.94 log units) above it; measured number below the stated range.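

Chloro in place of hydrogen on an aromatic carbon, ortho to a fluoro group and meta to a large group, gives an at least 86-fold lower number from compound 1 to compound 4 (1.93 log units; beyond the scatter) in this assay. For the compounds shown here, the earlier compounds only exchanged one group for another at a different place on the same ring, and none of those steps can be read, so this is the first change to the shared core with a clear direction. A single added chlorine atom at this position is enough to bring the series to a measurable value, and compound 4 is the only compound shown that leaves the limit: the limit of > 30000 nM in this assay, at which 3 of the 4 values shown sit.

Going by these compounds, what a methyl group, a bromo group or an amine would do at this same position stays open, so it cannot be said whether the gain belongs to chloro alone or would come with other groups as well. Also open, on these data alone, is whether the fluoro group on the same ring is needed for the gain, which a compound carrying the chloro group with hydrogen in place of that fluoro group could answer.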